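Methyl-to-hydroxy swap on the benzyl ring of compound 3

The source may report more compounds than this note shows. Statements on the series, on what has been measured and on what is new or still open speak of the compounds shown alone.

Three compounds of the series have numbers in a functional assay on KYSE-450 cells (Homo sapiens) for inhibition, read by MTT assay, with a stated time of 48 h; a higher number here means a weaker inhibitor, a lower number a stronger inhibitor. Compound 1 `C/C=C/C(=O)N(Cc1cc(OC)c(OC)c(OC)c1)c1ccc(OC)c(O)c1` gives 9160 nM in this assay. Compound 2 `COc1ccc(CNc2cc(OC)c(OC)c(OC)c2)cc1C` gives 73800 nM in this assay. Compound 3 `C/C=C/C(=O)N(Cc1ccc(OC)c(C)c1)c1cc(OC)c(OC)c(OC)c1` gives 32900 nM in this assay and stands second highest of the three numbers, nearer to compound 2 than to compound 1. Among the compounds with values here, the only step between compounds that differ in one place, a 2.2-fold lower number from compound 2 to compound 3 (0.35 log units; beyond the scatter), concerns (prop-1-en-1-yl)carbonyl in place of hydrogen on a nitrogen on an aromatic ring and is modest.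

Compound 4 `C/C=C/C(=O)N(Cc1ccc(OC)c(O)c1)c1cc(OC)c(OC)c(OC)c1` has not been measured. It differs from compound 3 by hydroxy in place of methyl on an aromatic carbon. Within the data shown here, no measured step covers this change, so no direct precedent exists. Compound 1, which also carries a hydroxy ortho to a methoxy group though on the other aromatic ring, gives 9160 nM, the lowest number of the three; compound 4 is not a one-place step from compound 1, so only the two values can be compared. On this basis a lowering of modest size is expected from compound 3 to compound 4, a 2.2-fold lower number from compound 3 to compound 4 (0.34 log units; beyond the scatter), with wide uncertainty. Compound 4 is estimated at 15000 nM in this assay, within a range of 4000 nM to 50000 nM.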

Compound 4, half-maximal inhibitory concentration: 67 nM
For compound 4 the middle estimate is 220-fold (2.35 log units) above the measured one, and the stated range ends above it.
By their numbers in this assay, from the lowest: compound 4; then compound 1; then compound 3; then compound 2.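

In this assay the swap of methyl for hydroxy, on an aromatic carbon ortho to a methoxy group, gives a 490-fold lower number from compound 3 to compound 4 (2.69 log units; beyond the scatter) and so far outweighs the other one-place change, a 2.2-fold lower number from compound 2 to compound 3 (0.35 log units; beyond the scatter) on the same 4-methoxy-3-methylphenyl background. This position is therefore highly sensitive to the group it carries, since exchanging one heavy atom moves the number much further than adding the (prop-1-en-1-yl)carbonyl on the nitrogen does. The move to 3-hydroxy-4-methoxyphenyl enters 1 hydrogen-bond donor and 1 hydrogen-bond acceptor, but nothing at hand shows what lies behind the size of the step.

From the compounds shown here alone, it remains open whether hydroxy is specifically required at this carbon, which an amine or a fluorine at the same place would help to settle. Also open, going by these compounds, is whether a step of this size persists in compound 4 when the (prop-1-en-1-yl)carbonyl on the nitrogen gives way to hydrogen or to an acetyl group.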